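The compounds below may be only part of what the source reports. "The series", "measured", "known", "first", "only" and "open" are said of these compounds alone.

Compound 1, with the structure `N/C(=N\NC(=S)N1CCCCCC1)c1ccccn1`, and compound 2, with the structure `N/C(=N\NC(=S)N1CCSCC1)c1ccccn1`, share most of their build but differ in the ring that hangs from the thiocarbonyl group; the difference between the two cores is not broken down here. Compound 3, with the structure `N/C(=N\NC(=S)N1CCSCC1)c1ccc(F)cn1`, carries the same core as compound 2 with one change, (fluoro in place of hydrogen on an aromatic carbon). Compound 4, with the structure `N/C(=N\NC(=S)N1CCCCCC1)c1ccc(F)cn1`, has not yet been measured; it carries the core of compound 1 with one change, (fluoro in place of hydrogen on an aromatic carbon). The place of the change is described in the same words in both pairs, so it is the same change made on two different cores.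

In a functional assay on HeLa cells (Homo sapiens) for cytotoxicity, read by MTT assay, with a stated time of 72 h, tested at 100 uM (a higher number here means more inhibition of growth at the concentration tested, a lower number less inhibition of growth), compound 1 gives 88.7%. In this assay compound 2 gives 88.7%, and compound 3 gives 88.1%. The step from compound 2 to compound 3 is a number 0.6 percentage points lower from compound 2 to compound 3 (within the scatter), and all three numbers lie within the scatter of one another, so none of them can be ranked above the others.

For compound 4 the step from compound 1 is expected to be a number 0.7 percentage points lower from compound 1 to compound 4 (within the scatter), resting on the same change giving a number 0.6 percentage points lower from compound 2 to compound 3 (within the scatter) on the neighbouring core. Compound 4 is therefore estimated to reach 88%, most likely between 80% and 94%.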

Compound 4, percent growth inhibition at one concentration: 85.6%
Beside the measured number, compound 4's estimate is 2.4 percentage points above it; the range from low to high includes it.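

In this assay, fluoro in place of hydrogen on an aromatic carbon of the core of compound 1 gives a number 3.1 percentage points lower from compound 1 to compound 4 (within the scatter). Set beside the same change on the core of compound 2, this step does not stand apart from the earlier one, so in these two pairs the change carries from one core to the other without a difference that can be read: the same change on two cores in this assay, a number 0.6 percentage points lower (within the scatter) from compound 2 to compound 3 and a number 3.1 percentage points lower (within the scatter) from compound 1 to compound 4, 2.5 percentage points apart, within the scatter of two such steps. This does not show that fluoro has any effect of its own on either core, since neither step rises above the scatter, and two pairs read at a single concentration cannot establish a rule for the whole series.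

The compounds shown leave open whether a group other than fluoro, such as chloro, methoxy, an amine or a carboxylic acid, would give a step beyond the scatter at this same place on the ring, and whether fluoro would behave the same way at another carbon of that ring. They also leave open whether the two steps would still agree on a core that carries an open longer chain in place of the ring hanging from the thiocarbonyl group.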